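The source may report more compounds than this note shows. Statements on the series, on what has been measured and on what is new or still open speak of the compounds shown alone.

Working notes on the series. Compound 1 `N#Cc1ccc(CSc2nc(CN3CCCc4ccccc43)c(I)c(=O)[nH]2)cc1` reaches only the limit of an ADME assay on HepG2 2.2.15 cells (Homo sapiens) for cytotoxicity, read by MTT assay, with a stated time of 72 h (a lower number here means that less compound is tolerated, a higher number that more compound is tolerated), giving > 100000 nM, which is a limit and not a number. Compound 2 `O=c1[nH]c(SCc2ccc([N+](=O)[O-])cc2)nc(Cc2ccccc2)c1I` gives 52700 nM in this assay. Compound 3 `Cc1cc(C)cc(Cc2nc(SCCOc3ccc([N+](=O)[O-])cc3)[nH]c(=O)c2I)c1` gives 96600 nM in this assay, the highest of the two numbers, with compound 2 as nearest neighbour within the scatter. Compound 4 `Cc1cc(C)cc(Cc2nc(SCCOc3ccccc3)[nH]c(=O)c2I)c1` remains to be measured in this assay; it differs from compound 3 by hydrogen in place of nitro on an aromatic carbon. For the measured compounds named here, no step between measured compounds is known, so the step from compound 3 to compound 4 in this assay is expected to be small, at most within the scatter, as a 1.0-fold higher number from compound 3 to compound 4 (0.02 log units; within the scatter). Compound 4 is therefore estimated at 100000 nM in this assay, with a range from 45000 nM to 220000 nM, and a fair chance of only a limit being reported.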

Compound 4, half-maximal cytotoxic concentration: > 100000 nM
Compound 4 gave a limit, no number (the forecaster's own chance of this, stated with the estimate: 55%); the middle value lies on the limit itself.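

In this assay, for the compounds shown here, going from 4-nitrophenoxy to phenoxy, on an aromatic carbon para to a large group, gives an at least 1.0-fold higher number from compound 3 to compound 4 (0.01 log units; that floor lies within the scatter), the first step that can be read. Losing the nitro therefore brings no drop in the number here. The size of the change cannot be read, because the result sits on a limit: the limit of > 100000 nM in this assay, at which 2 of the 4 values shown sit.

The compounds shown leave open whether an amine or a carboxylic acid at this place would lower the number. From the compounds shown here alone, it also stays open whether the same change behaves alike with a longer chain.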